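This account rests on a few compounds, and the source may have more. Where it says the series, first, only, none or still open, it means among the compounds named here.

In a functional assay on U-937 cells (Homo sapiens) for cytotoxicity, read by MTT assay, with a stated time of 24 h (a lower number here means a stronger inhibitor, a higher number a weaker inhibitor), compound 1 `BrCCCCCCOc1c(Br)cc(Br)cc1Oc1ccc(Br)cc1Br` gives 33.8 ug/mL, and compound 2 `CC(C)(C)C(=O)C(C#N)Oc1c(Br)cc(Br)cc1Oc1ccc(Br)cc1Br` gives 32.5 ug/mL. Within the data shown here, compound 2 therefore stands level with its only measured neighbour, with the two values lying within the scatter of each other. Compound 3 `BrCCOc1c(Br)cc(Br)cc1Oc1ccc(Br)cc1Br` keeps the shared core and differs from compound 2 by one change: 2-bromoethyl in place of cyano((tert-butyl)carbonyl)methyl on an oxygen on an aromatic ring. In words, this is 2-bromoethyl in place of cyano((tert-butyl)carbonyl)methyl on an oxygen on an aromatic ring. Among the measured compounds shown here, one measured step bears on it, a 1.0-fold lower number from compound 1 to compound 2 (0.02 log units; within the scatter), which links the same cyano((tert-butyl)carbonyl)methyl group to 6-bromohexyl and stays within the scatter. For the measured compounds named here, no measured compound carries 2-bromoethyl, so this single step is thin evidence, and no shift beyond the scatter is expected in this assay. The expected step is a 1.0-fold higher number from compound 2 to compound 3 (0.02 log units; within the scatter). For compound 3 the estimated value is 34 ug/mL, with an expected range of 18 ug/mL to 62 ug/mL.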

Compound 3, half-maximal inhibitory concentration: 32.5 ug/mL
For compound 3 the middle estimate is 1.0-fold (0.02 log units) above the measured one; the measured number falls inside the stated range.
By their numbers in this assay, from the lowest: compounds 2, 3 and 1 (each within the scatter of the next).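

In this assay, putting 2-bromoethyl on the oxygen in place of cyano((tert-butyl)carbonyl)methyl gives no change at the digits printed from compound 2 to compound 3 (within the scatter), so this position accepts a group with neither nitrile nor carbonyl and with fewer heavy atoms without the number leaving the scatter. Cutting the bromoalkyl chain from 6-bromohexyl to 2-bromoethyl gives a 1.0-fold lower number from compound 1 to compound 3 (0.02 log units; within the scatter), which shows for the first time that chain length, across these two chains, does not separate the compounds in this assay. No measurement in hand accounts for why these three groups read alike.

As far as these compounds go, whether an amine or a carboxylic acid on this oxygen would move the number beyond the scatter remains open. So does whether a plain hexyl chain carrying no bromine would read the same as compound 1.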